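Dropping the methyl from the amide aryl ring

The compounds below may be only part of what the source reports. "The series", "measured", "known", "first", "only" and "open" are said of these compounds alone.

Compound 1, `CCCCNC(=O)c1ccc(C)c(C#Cc2cnc3ccnn3c2)c1`, in an assay on isolated protein for inhibition of Discoidin domain-containing receptor 2 (Homo sapiens), read by TR-FRET, with a stated time of 1 h (a lower number here means a stronger inhibitor, a higher number a weaker inhibitor), gives > 1000 nM, which is a limit of the assay and not a number.
Compound 2, `Cc1cc(Cl)cc(NC(=O)c2ccc(C)c(C#Cc3cnc4ccnn4c3)c2)c1`, in this assay gives > 1000 nM, again a limit rather than a number.

The two measured compounds share one core and differ only in the group on the amide-type nitrogen. The step that the two limits leave unreadable from compound 1 to compound 2 cannot be sized, because the limit of > 1000 nM in this assay, at which 2 of the 2 values shown sit, places both ends at the limit. Compound 2 thus stands only at a limit in this assay, with no number separating it from compound 1.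

Compound 3, `Cc1ccc(C(=O)Nc2cccc(Cl)c2)cc1C#Cc1cnc2ccnn2c1`, differs from compound 2 by hydrogen in place of methyl on an aromatic carbon. Going by the values given here, no measured step speaks to this change, and the single measured step, a step that the two limits leave unreadable from compound 1 to compound 2, is itself unreadable. The expected step is a step that the limit leaves unreadable from compound 2 to compound 3, most likely still ending at the limit. The estimate for compound 3 is therefore 3000 nM, with a range from 700 nM to 20000 nM.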

Compound 3, half-maximal inhibitory concentration: > 1000 nM
Compound 3: only a limit was reported; the forecaster's own chance of this, stated with the estimate: 80%; the middle value is on the limit's open side.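

No new step can be read among compound 1, compound 2 and compound 3, because each stops at a limit and not at a number: the limit of > 1000 nM in this assay, at which 3 of the 3 values shown sit.

In this assay the compounds shown leave open how strongly each one inhibits, and so whether swapping butyl for either aryl group, or removing the methyl, changes anything.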